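Amino for chloro on the fused core: cytotoxicity estimate

The compounds below may be only part of what the source reports. "The series", "measured", "known", "first", "only" and "open" are said of these compounds alone.

Measured compounds in a functional assay on NCI-H522 cells (Homo sapiens) for cytotoxicity, read by sulforhodamine B assay, with a stated time of 48 h; a higher number here means that more compound is tolerated, a lower number that less compound is tolerated: compound 1 `ClCc1ccccc1Cn1cnc2c(Cl)ncnc21` gives > 100000 nM, a limit of the assay. Compound 2 `ClCc1cccc(Cn2cnc3c(Cl)ncnc32)c1` gives > 100000 nM, likewise a limit. Compound 3 `ClCc1cccc(Cn2cnc3c(Cl)nc(Cl)nc32)c1` gives 17000 nM.

Going by the values given here, compound 3 holds the only numeric value; the other two sit at the limit of > 100000 nM in this assay, at which 2 of the 3 values shown sit. Compound 4 `Nc1nc(Cl)c2ncn(Cc3cccc(CCl)c3)c2n1` is not yet measured. It differs from compound 3 by amino in place of chloro on an aromatic carbon. Among the compounds with values here, the one measured step, an at least 5.8-fold lower number from compound 2 to compound 3 (0.76 log units; beyond the scatter), concerns adding chloro at this place, not replacing it by amino, so it bears only loosely. Removing the chloro that produced that step suggests a move back toward the limit, tempered by the amino entering. For compound 4 the expected step is a 2.1-fold higher number from compound 3 to compound 4 (0.31 log units; beyond the scatter), giving an estimate of 35000 nM (range 9000 nM to 100000 nM).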

Compound 4, concentration lethal to 50% of the cells: 81300 nM
Estimate against measurement, compound 4: 2.3-fold (0.37 log units) below; measured number inside the range.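

In this assay, the place between two ring nitrogen atoms proves sensitive to which group sits there: amino in place of chloro gives a 4.8-fold higher number from compound 3 to compound 4 (0.68 log units; beyond the scatter), so amino does not keep the lower number seen with chloro. Amino in place of hydrogen gives an at least 1.2-fold lower number from compound 2 to compound 4 (0.08 log units; that floor lies within the scatter), which does not separate the two groups. Compound 2 stands at a limit of the assay, so this comparison has no upper end: the limit of > 100000 nM in this assay, at which 2 of the 4 values shown sit.

Open, from the compounds shown here alone, is whether a bromo or a methoxy group at this place would match chloro. Also open, going by these compounds, is whether amino behaves the same with the side chain arranged as in compound 1.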